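Side-chain exchange on a dihydropyridine aorta inhibitor

A few compounds are considered here, and "the series" means these few. Any claim that something is new, unique, unknown or untested is made for them only; others in the source may bear on it.

Compound 1: `CCO/C(O)=C1\C(COCCNc2n[nH]c(N)n2)=NC(C)=C(C(=O)OC)C1c1cccnc1Cl`, 316 nM
Compound 2: `CCO/C(O)=C1\C(COCCNc2n[nH]c(N)n2)=NC(C)=C(C(=O)OC)C1c1cccc(C(F)(F)F)c1Cl`, 3.98 nM
Compound 3: `CCO/C(O)=C1\C(COCC/N=C(/N)S)=NC(C)=C(C(=O)OC)C1c1cccc(Cl)c1Cl`, 1 nM

In a functional assay (aorta) with Rattus norvegicus as the target (a lower number here means a stronger inhibitor, a higher number a weaker inhibitor), compound 3 gives the lowest number of the three, with compound 2 nearest and compound 1 furthest. Compound 4 is `CCO/C(O)=C1\C(COCCNc2cc(NC)ncn2)=NC(C)=C(C(=O)OC)C1c1cccc(Cl)c1Cl`, and it differs from compound 3 by a group of 9 heavy atoms (5 carbon, 4 nitrogen; one six-membered aromatic ring with 2 hetero atoms) in place of a group of 4 heavy atoms (1 carbon, 2 nitrogen, 1 sulfur; no ring), on a saturated chain carbon, two bonds along the chain from an oxygen on a saturated carbon. Among the measured compounds shown here, the only measured single step, a 79-fold lower number from compound 1 to compound 2 (1.90 log units; beyond the scatter), concerns the aryl group on the saturated ring carbon, not the side chain, so no measured step bears directly on this change. Compounds 2 and 3 differ in two places and only show that both are potent. With the aryl group of compound 3 kept, compound 4 is expected to remain potent, with a step of a 3.0-fold higher number from compound 3 to compound 4 (0.48 log units; beyond the scatter). Compound 4 is therefore estimated at 3 nM, between 0.8 nM and 12 nM.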

Compound 4, half-maximal inhibitory concentration: 3.16 nM
Beside the measured number, compound 4's estimate is 1.1-fold (0.02 log units) below it, and the stated range covers the measured number.
By their numbers in this assay, from the lowest: compound 3; then compounds 4 and 2 (each within the scatter of the next); then compound 1.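

With the aryl group held fixed, the side chain in this assay accepts a much larger ring-bearing group: (6-(methylamino)pyrimidin-4-yl)amino, with 9 heavy atoms, replaces the open-chain group of 4 heavy atoms, giving a 3.2-fold higher number from compound 3 to compound 4 (0.50 log units; beyond the scatter). The step is modest, so this position does not require the sulfur-bearing open-chain group for a strong inhibitor. No measurement shown accounts for the size of this step. From the compounds shown here alone, whether a plain primary amine, a carboxylic acid or a longer chain would fare as well at this place remains open.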